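A few compounds are considered here, and "the series" means these few. Any claim that something is new, unique, unknown or untested is made for them only; others in the source may bear on it.

Of the compounds shown here, three have been tested in an assay on cells for inhibition of cytochrome P450 11B2, mitochondrial (Homo sapiens), read by HTRF (on this read-out lower numbers stand for stronger inhibition and higher numbers for weaker inhibition), so far. Compound 1, with the structure `CCC(=O)NCc1cncc(N2C(=O)c3ccc(Cl)cc3C2(C)C)c1`, gives 282 nM in this assay. Compound 2, with the structure `O=C1c2ccccc2CN1c1cccnc1`, gives 1120 nM, a higher number than compound 1 and a difference beyond the usual scatter. Compound 3, with the structure `CCC(=O)N[C@@H]1CCCc2c1cncc2N1CCc2cc(Cl)ccc2C1=O`, gives 119 nM, a lower number than compound 1, again beyond the scatter. Compound 1 therefore stands in the middle of the three: weaker than compound 3 and stronger than compound 2, without being the strongest or the weakest of the set.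

The next compound, compound 4, has the structure `CC(=O)NCc1cncc(N2C(=O)c3ccc(Cl)cc3C2(C)C)c1`. It differs from compound 1 in a single place: hydrogen in place of methyl on a saturated chain carbon bound to a carbonyl carbon. Within the data shown here, no pair of measured compounds shows this kind of change, so nothing measured tells how large its effect is. Shortening the chain on the amide by one carbon is a small change, and the shared core, which carries the chlorine-bearing ring, is untouched. The step from compound 1 to compound 4 is expected to be small, at most a modest rise in the number, possibly none beyond the scatter; the estimate means a change of a 1.2-fold higher number from compound 1 to compound 4 (0.09 log units; within the scatter). Compound 4 is expected to give about 350 nM, in a range from 180 nM to 700 nM.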

Compound 4, half-maximal inhibitory concentration: 59 nM
Compound 4: middle estimate off by 5.9-fold (0.77 log units), on the high side; measured number outside the range, below it.
By their numbers in this assay, from the lowest: compounds 4 and 3 (each within the scatter of the next); then compound 1; then compound 2.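

Going from propanoyl to acetyl gives a 4.8-fold lower number from compound 1 to compound 4 (0.68 log units; beyond the scatter) in this assay, so this place on the amide chain responds clearly to the loss of a single methyl, a change that adds or removes no ring, no charge and no hydrogen-bond donor or acceptor. Among these compounds, this is the first measured step at this position, and it points in the direction of stronger inhibition for the shorter of the two chains, with the shared core left untouched. No measured evidence bearing on the cause of this step is available.

As far as these compounds go, with only propanoyl and acetyl to go on, two chain lengths cannot show a trend, so it remains open whether the number would keep falling with a formyl group or rise again with a longer chain such as butanoyl. From the compounds shown here alone, it is also open whether acetamido in place of propanoylamino would have a similar effect on compound 3, which carries the same propanoylamino group on a different core.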